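This account rests on a few compounds, and the source may have more. Where it says the series, first, only, none or still open, it means among the compounds named here.

Compound 1 `CCN(CC)c1ccc(-c2cccc(Cl)c2)nn1`: > 25000 nM
Compound 2 `CCN(CC)c1ccc(-c2ccc(C#N)cc2)nn1`: > 25000 nM

Both entries are limits of the assay and not numbers. In a functional assay on NCI-H727 cells (Homo sapiens) for antiproliferative activity, with a stated time of 48 h (on this read-out lower numbers stand for stronger inhibition and higher numbers for weaker inhibition), compound 2 gives > 25000 nM, which is a limit. Compound 1 shares that result, so the whole evidence so far is the limit of > 25000 nM in this assay, at which 2 of the 2 values shown sit, and no number separates the two compounds.

The next compound, compound 3 `CCN(CC)c1ccc(-c2ccc(C(=O)O)cc2)nn1`, keeps the shared core of compound 2. It carries a carboxy group in place of the cyano group on an aromatic carbon, para to a large group: carboxy in place of cyano on an aromatic carbon.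

For the measured compounds named here, no measured step yet shows what a change at this place does in this assay. The expectation therefore rests on compound 2 with its limit of > 25000 nM, and no gain in inhibition is foreseen. The estimated step that the limit leaves unreadable from compound 2 to compound 3 is expected to be none beyond the scatter. A report of only a limit is the likeliest outcome. For compound 3 the expected value is 30000 nM, with an estimated range of 12000 nM to 60000 nM.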

Compound 3, half-maximal inhibitory concentration: > 25000 nM
Compound 3 was reported as a limit (the forecaster's own chance of this, stated with the estimate: 85%); the middle value is on the limit's open side.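

In this assay compound 3 gives > 25000 nM as a limit and not a number. Compound 2 also stands at a limit, so no step can be read between compound 2 and compound 3. The compounds shown leave open how strongly any of them inhibits, since all share one result: the limit of > 25000 nM in this assay, at which 3 of the 3 values shown sit.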